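The compounds below may be only part of what the source reports. "The series", "measured", "known", "first", "only" and "open" are said of these compounds alone.

Compound 1, with the structure `O=C(NS(=O)(=O)c1ccccc1)c1cccnc1`, pairs a pyridine amide with a benzenesulfonyl group. In a functional assay on MCF7 cells (Homo sapiens) for antiproliferative activity, read by MTT assay, with a stated time of 48 h (on this read-out higher numbers stand for weaker inhibition and lower numbers for stronger inhibition), compound 1 gives 14400 nM. Compound 2, with the structure `Cc1ccc(S(=O)(=O)NC(=O)c2cccnc2)cc1`, carries one extra group: methyl in place of hydrogen on an aromatic carbon. In this assay compound 2 gives 12000 nM, so the change made a 1.2-fold lower number from compound 1 to compound 2 (0.08 log units; within the scatter). Compound 3, with the structure `Cc1ccc(C(=O)NS(=O)(=O)c2ccccc2)c(Cl)n1`, has a different core from compound 1; the difference between the two cores is not broken down here. In this assay compound 3 gives 13400 nM, which sits within the scatter of both compound 1 and compound 2.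

Compound 4, with the structure `Cc1ccc(S(=O)(=O)NC(=O)c2ccc(C)nc2Cl)cc1`, has not yet been measured. It differs from compound 3 by the same change that turned compound 1 into compound 2: methyl in place of hydrogen on an aromatic carbon. The surroundings of the place are described in the same words in both cases.

Because the earlier step was a 1.2-fold lower number from compound 1 to compound 2 (0.08 log units; within the scatter), the step from compound 3 to compound 4 is expected to be small as well, about a 1.2-fold lower number from compound 3 to compound 4 (0.07 log units; within the scatter). Compound 4 is therefore estimated to give 11500 nM in this assay, with a likely range from 6000 nM to 22000 nM.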

Compound 4, half-maximal inhibitory concentration: 8520 nM
The estimate for compound 4 lay 1.3-fold (0.13 log units) above the measured number; low and high end bracket the measured number.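

In this assay the change from phenyl to 4-methylphenyl gives a 1.6-fold lower number from compound 3 to compound 4 (0.20 log units; within the scatter), so on this second core the step again stays inside the usual spread of repeated measurements. Set beside the earlier step, the new one agrees with it: the same change on two cores in this assay, a 1.2-fold lower number (0.08 log units; within the scatter) from compound 1 to compound 2 and a 1.6-fold lower number (0.20 log units; within the scatter) from compound 3 to compound 4, 1.3-fold (0.12 log units) apart, within the scatter of two such steps. This shows that the change carried from one core to the other without any difference that can be told apart from scatter, but it does not show that the methyl group really lowers the number, and two cores say nothing about how the change would behave on any other core in the series.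

The compounds shown leave open whether a different group at this place on the ring, such as a methoxy group, an amine or a carboxylic acid, would give a step beyond the scatter. They also leave open how a longer chain there, such as ethyl or propyl, would read in this assay.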